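This account rests on a few compounds, and the source may have more. Where it says the series, first, only, none or still open, it means among the compounds named here.

Measured in a functional assay on SNB-75 cells (Homo sapiens) for inhibition, read by sulforhodamine B assay, with a stated time of 48 h; on this read-out lower numbers stand for stronger inhibition of growth and higher numbers for weaker inhibition of growth:
- compound 1 `CCCCCCCCCCCC[C@@H](O)[C@H]1CC[C@H]([C@H](O)CCCCCCCCCCNC(=O)c2ccnn2C)O1`: 50100 nM
- compound 2 `CCCCCCCCCCCC[C@@H](O)[C@H]1CC[C@H]([C@H](O)CCCCCCCCCCNCc2ccnn2C)O1`: 2000 nM

Compound 2 holds the lower of the two numbers. Among the compounds with values here, the only measured step, a 25-fold lower number from compound 1 to compound 2 (1.40 log units; beyond the scatter), is large and beyond the scatter. It puts (1-methyl-1H-pyrazol-5-yl)methyl in place of (1-methyl-1H-pyrazol-5-yl)carbonyl on an amine nitrogen.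

Compound 3 `CCCCCCCCCCCC[C@@H](O)[C@H]1CC[C@H]([C@H](O)CCCCCCCCCCC(=O)Nc2ccnn2C)O1` is the next to be read: (1-methyl-1H-pyrazol-5-yl)carbamoyl in place of ((1-methyl-1H-pyrazol-5-yl)methyl)amino on a saturated chain carbon, ten or more bonds along the chain from an oxygen on a saturated carbon and a saturated ring carbon. The change lies on a saturated chain carbon. Its carbamoyl group brings back a carbonyl, as in compound 1 at 50100 nM, though in a different arrangement. That step therefore bears on the change only indirectly. In this assay, a sizeable move to a higher number is expected, and the estimated step is a 10-fold higher number from compound 2 to compound 3 (1.00 log units; beyond the scatter). Compound 3 is expected at 20000 nM, with an estimated range of 5000 nM to 70000 nM.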

Compound 3, concentration for 50% growth inhibition: 100000 nM
Compound 3: middle estimate off by 5.0-fold (0.70 log units), on the low side; measured number above the stated range.
By their numbers in this assay, from the lowest: compound 2; then compounds 1 and 3 (each within the scatter of the next).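

In this assay the move to (1-methyl-1H-pyrazol-5-yl)carbamoyl gives a 50-fold higher number from compound 2 to compound 3 (1.70 log units; beyond the scatter) and leaves compound 2, with its amine link and no carbonyl, alone at the low end of the three numbers. The two carbonyl-bearing links are not separated, since a 2.0-fold higher number from compound 1 to compound 3 (0.30 log units; within the scatter) shows that the direction of the amide on this saturated chain makes no readable difference in this assay and that the amine link is so far the only one with a clearly lower number. No supporting data bear on the reason for this result.

Still open, going by these compounds, is whether an ether or a sulfonamide link would fall with compound 2 or with compounds 1 and 3. On these data alone, it is also open whether a phenyl group in place of 1-methyl-1H-pyrazol-5-yl would keep the number of compound 2.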